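The source may report more compounds than this note shows. Statements on the series, on what has been measured and on what is new or still open speak of the compounds shown alone.

Compound 1 `S=C(Nc1ccccc1)Nc1ccc2[nH]ccc2c1` gives in an ADME assay on cells for inhibition of Amine oxidase [flavin-containing] A (Homo sapiens), read by spectrophotometry; a higher number here means a weaker inhibitor, a lower number a stronger inhibitor > 30000 nM, which is a limit of the assay and not a number.
Compound 2 `CC(=O)c1ccc(NC(=S)Nc2ccc3[nH]ccc3c2)cc1` gives in this assay 67000 nM.

Compound 1 therefore stands only at a limit in this assay, recorded as the limit of > 30000 nM in this assay, at which 1 of the 2 values shown sits, so no number for its potency is known. Compound 2 carries an acetyl in place of hydrogen on an aromatic carbon and gives a weak number; the step that the limit leaves unreadable from compound 1 to compound 2 cannot be read in size, since one side of it is a limit.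

Compound 3 `O=C(c1ccccc1)c1ccc(NC(=S)Nc2ccc3[nH]ccc3c2)cc1` differs from compound 1 by benzoyl in place of hydrogen on an aromatic carbon. Among the compounds with values here, the one measured step that bears on this change is a step that the limit leaves unreadable from compound 1 to compound 2, and its size is unreadable, so it offers no guide to direction or magnitude. What the two measured compounds share is weak inhibition throughout, and no strong inhibition is expected here. The step that the limit leaves unreadable from compound 1 to compound 3 is expected to be none beyond the scatter, with a fair chance that compound 3 again returns only a limit. The estimate for compound 3 in this assay is 60000 nM, within a range from 20000 nM to 200000 nM.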

Compound 3, half-maximal inhibitory concentration: "not active" (no number reported)
The entry for compound 3 holds no number; there is nothing to compare the estimate with.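

Within the data shown here, compound 3 is entered as not active in this assay, with no number, so no step from compound 1 to compound 3 can be read. Compound 1 offers only a limit: the limit of > 30000 nM in this assay, at which 1 of the 3 values shown sits.

The compounds shown leave open whether benzoyl in compound 3 changes inhibition at all, relative to compound 1 or to the acetyl of compound 2.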